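Swapping the aryl pattern on a urea-linked series

This account rests on a few compounds, and the source may have more. Where it says the series, first, only, none or still open, it means among the compounds named here.

Four compounds share the same general shape: a urea linking a substituted phenyl to an aryl group, which carries an amide to a phenylethyl end. Compound 1 `CC(NC(=O)C#Cc1ccc(NC(=O)Nc2cc(C(F)(F)F)ccc2Cl)cc1)c1ccccc1` and compound 2 `CC(NC(=O)C#Cc1ccc(NC(=O)Nc2ccc(Cl)c(C(F)(F)F)c2)cc1)c1ccccc1` differ only by 4-chloro-3-(trifluoromethyl)phenyl in place of 2-chloro-5-(trifluoromethyl)phenyl on an amide-type nitrogen. In a functional assay on MX1 cells (Homo sapiens) for inhibition, read by MTT assay, with a stated time of 120 h (on this read-out higher numbers stand for weaker inhibition and lower numbers for stronger inhibition), compound 1 gives 16100 nM and compound 2 gives 12800 nM, so that a 1.3-fold lower number from compound 1 to compound 2 (0.10 log units; within the scatter). Compound 3 `CC(NC(=O)c1ccc(-c2ccc(NC(=O)Nc3cc(C(F)(F)F)ccc3Cl)cc2)cc1)c1ccccc1` has a different core; the difference between the two cores is not broken down here. In this assay compound 3 gives 17700 nM, which sits within the scatter of the numbers for compound 1 and compound 2. Within the data shown here, compound 4 `CC(NC(=O)c1ccc(-c2ccc(NC(=O)Nc3ccc(Cl)c(C(F)(F)F)c3)cc2)cc1)c1ccccc1` has not been measured; it differs from compound 3 by 4-chloro-3-(trifluoromethyl)phenyl in place of 2-chloro-5-(trifluoromethyl)phenyl on an amide-type nitrogen, at the same place in both pairs, so this is the same change as the one from compound 1 to compound 2. That earlier change stayed within the scatter, and a step of similar size is expected here, a 1.3-fold lower number from compound 3 to compound 4 (0.10 log units; within the scatter). In this assay compound 4 is estimated to give 14000 nM, most likely between 7000 nM and 28000 nM.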

Compound 4, half-maximal inhibitory concentration: 4630 nM
Compound 4: middle estimate off by 3.0-fold (0.48 log units), on the high side; the measured number lies below the stated range.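

The effect of this change did not carry over intact from one core to the other. In this assay, putting 4-chloro-3-(trifluoromethyl)phenyl in place of 2-chloro-5-(trifluoromethyl)phenyl gives a 3.8-fold lower number from compound 3 to compound 4 (0.58 log units; beyond the scatter), and the size of the step depends on the core that carries it: the same change on two cores in this assay, a 1.3-fold lower number (0.10 log units; within the scatter) from compound 1 to compound 2 and a 3.8-fold lower number (0.58 log units; beyond the scatter) from compound 3 to compound 4, 3.0-fold (0.48 log units) apart, beyond the scatter of two such steps. This means that, within this series, the step measured on one core was a poor guide to the size of the step on the other, but two pairs do not explain why the cores differ or predict the step on any third core.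

The compounds shown leave open whether the larger step would hold if other parts of the core of compound 3 were altered. They also leave open how these numbers would respond if the phenylethyl end gave way to a longer chain, or if it carried an amine or a carboxylic acid.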